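The source may hold more compounds than are shown below. What is called first, only, known or untested is meant among the compounds shown, and "the series" means these compounds.

Measured in a functional assay on the whole organism with Rattus norvegicus as the target; a higher number here means that more compound is needed for the effect, a lower number that less compound is needed:
- compound 1 `O=C(O)C(=O)Nc1nc(-c2ccccc2)cs1`: > 3 mg/kg (a limit of the assay, not a number)
- compound 2 `O=C(O)C(=O)Nc1nc(-c2ccc(O)cc2)cs1`: about 0.1 mg/kg
- compound 3 `CCOC(=O)C(=O)Nc1nc(-c2ccccc2OC)cs1`: about 1 mg/kg

Compound 3, at about 1 mg/kg, is the higher of the two actual numbers. Compound 2 stands lower at about 0.1 mg/kg, a gap beyond the scatter.

Compound 4 `COc1ccccc1-c1csc(NC(=O)C(=O)O)n1` carries hydrogen in place of ethyl on an oxygen next to a carbonyl group, that is, ethoxycarbonyl to carboxy.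

Within the data shown here, no measured step makes this change. The only one available, an at least 30-fold lower number from compound 1 to compound 2 (1.47 log units; beyond the scatter), is large, but it is hydroxy in place of hydrogen on an aromatic carbon, so it bears only indirectly. On these data alone, it does show that two carboxy compounds can lie far apart in this assay, so the direction stays open and the range must be wide. No shift beyond the scatter is expected as the central case, and the expected step is no change at the digits printed from compound 3 to compound 4 (within the scatter). For compound 4 the estimate is 1 mg/kg, with an expected range from 0.2 mg/kg to 5 mg/kg.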

Compound 4, dose for half-maximal effect: > 1 mg/kg
Compound 4: only a limit was reported; the forecaster's own chance of this, stated with the estimate: 25%; the middle value sits exactly at the limit.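

In this assay, among these compounds, the change from ethoxycarbonyl to carboxy gives a number no lower from compound 3 to compound 4 (the limit leaves the size open), so this is the first reading at this position, and it shows no gain from removing the ethyl. The value of compound 4 is a limit of the assay and not a number: the limit of > 1 mg/kg in this assay, at which 1 of the 4 values shown sits. The step between compound 1 and compound 4 cannot be read, since both values are limits, so the methoxy in compound 4 cannot be judged against hydrogen.

On these data alone, how far the number of compound 4 lies from that of compound 3 stays open, including whether the change has any effect beyond the scatter. Also open, as far as these compounds go, is what a longer chain such as propyl, or an amine, would do in place of ethyl on the oxygen next to a carbonyl group.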